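Chloro for methyl on the aromatic ring of compound 1

The compounds below may be only part of what the source reports. "The series", "measured", "known", "first", "only" and "open" are said of these compounds alone.

Measured so far:
Compound 1 `C#CCNC(=O)/C(C)=C(\C)c1ccc(C)cc1`: 120 mg/kg
Compound 2 `C/C(C(=O)NC1CC1)=C(/C)c1ccc(C)cc1`: 110 mg/kg

In a toxicity assay on the whole organism (strain Icem-CET (SPF Caw)) for cytotoxicity, with Mus musculus as the target (on this read-out lower numbers stand for an effect already at smaller amounts and higher numbers for an effect only at larger amounts of compound), compound 1 gives 120 mg/kg, the top of the two numbers shown, although the gap to compound 2 is only a 1.1-fold lower number from compound 1 to compound 2 (0.04 log units; within the scatter). Compound 2 itself gives 110 mg/kg in this assay.

Compound 3 `C#CCNC(=O)/C(C)=C(\C)c1ccc(Cl)cc1` has not yet been measured. Its difference from compound 1 is chloro in place of methyl on an aromatic carbon. For the measured compounds named here, the only measured step, from compound 1 to compound 2, swaps the group on the amide-type nitrogen at the other end of the molecule and leaves the aromatic ring untouched, so it does not speak directly to a change on the ring; it shows only that one alteration elsewhere stayed within the scatter. Going by the values given here, no measured pair shows what chloro in place of methyl does here. With nothing pointing either way, no step beyond the scatter is expected in this assay for compound 3, and the guess is that the read-out stays close to that of compound 1. Compound 3 is therefore estimated at 120 mg/kg, with a range of 60 mg/kg to 240 mg/kg. This estimate means a step of no change at the digits printed from compound 1 to compound 3 (within the scatter).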

Compound 3, dose for half-maximal effect: 60 mg/kg
Compound 3: the middle estimate sits 2.0-fold (0.30 log units) above what was measured; low and high end bracket the measured number.
By their numbers in this assay, from the lowest: compounds 3, 2 and 1 (each within the scatter of the next).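

In this assay, for the compounds shown here, the position para to a large group on the aromatic ring now has its first measured change, and chloro in place of methyl there gives a 2.0-fold lower number from compound 1 to compound 3 (0.30 log units; within the scatter), which is the first direct reading for this swap. This ring position, like the amide-type nitrogen in the earlier pair, therefore accepts a single change without the number leaving the usual scatter, although one pair cannot separate a small real shift from the noise between repeated measurements. No measurement on hand bears on the reason for this result.

On these data alone, it remains open whether other groups at this ring position, such as a methoxy group, a bromine atom or an amine, would move the number beyond the scatter, or whether a plain hydrogen there would do the same. As far as these compounds go, it is also open whether chloro on the ring would give a similar picture in compound 2, which carries cyclopropyl in place of propargyl on the amide-type nitrogen.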